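From pyridin-4-yl to 4-methylpyrimidin-2-yl on an amine nitrogen

This account rests on a few compounds, and the source may have more. Where it says the series, first, only, none or still open, it means among the compounds named here.

Three compounds on a shared core have been taken into a functional assay on VCaP cells (Homo sapiens) for antiproliferative activity, read by CCK-8 assay, with a stated time of 6 days; a lower number here means a stronger inhibitor, a higher number a weaker inhibitor. For compound 1 `C[C@@H](Cn1ccc(-c2ccc(C#N)c(Cl)c2)n1)NC(=O)c1ccccc1` the result reads "not determined" (no result reported). Compound 2 `C[C@@H](Cn1ccc(-c2ccc(C#N)c(Cl)c2)n1)NC(=O)C1CC(=O)C1` gives 22500 nM, and compound 3 `C[C@@H](Cn1ccc(-c2ccc(C#N)c(Cl)c2)n1)Nc1ccncc1` gives 9900 nM, the lower of the two numbers available.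

Compound 4 `Cc1ccnc(N[C@@H](C)Cn2ccc(-c3ccc(C#N)c(Cl)c3)n2)n1` carries 4-methylpyrimidin-2-yl in place of pyridin-4-yl on an amine nitrogen. Within the data shown here, only one measured step bears on this change. It sits on the same amine nitrogen and is modest: a 2.3-fold lower number from compound 2 to compound 3 (0.36 log units; beyond the scatter). That step replaced (3-oxocyclobutyl)carbonyl with pyridin-4-yl, whereas compound 4 exchanges one six-membered aromatic ring for another, so it gives only loose guidance and no clear direction. A step no larger than the scatter is therefore expected in this assay, and the estimated change is a 1.1-fold lower number from compound 3 to compound 4 (0.04 log units; within the scatter). For compound 4 the expected value is 9000 nM, with an estimated range of 3000 nM to 25000 nM.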

Compound 4, half-maximal inhibitory concentration: 850 nM
Compound 4: the middle estimate sits 11-fold (1.02 log units) above what was measured; measured number outside the range, below it.
By their numbers in this assay, from the lowest: compound 4; then compound 3; then compound 2.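

In this assay, among these compounds, the amine nitrogen proved far more sensitive to the choice of six-membered aromatic ring than the earlier compounds had suggested: a 12-fold lower number from compound 3 to compound 4 (1.07 log units; beyond the scatter), whereas the exchange of an acyl group for pyridin-4-yl had given only a 2.3-fold lower number from compound 2 to compound 3 (0.36 log units; beyond the scatter). Against the (3-oxocyclobutyl)carbonyl compound the gain is larger still, a 26-fold lower number from compound 2 to compound 4 (1.42 log units; beyond the scatter), and compound 4 now holds the lowest number of the series with a reported result. The data shown offer no measurement that accounts for this gain.

Compound 3 and compound 4 differ both in the ring, with its added nitrogen, and in the methyl group, so the step cannot be assigned to either alone. From the compounds shown here alone, a plain pyrimidin-2-yl or a 4-methylpyridin-2-yl on the same amine nitrogen would separate the two, and whether an ethyl group in place of the methyl keeps the gain also remains open.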